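Cytotoxicity notes on diyne-linked deoxyuridines, compounds 2 and 3

The compounds below may be only part of what the source reports. "The series", "measured", "known", "first", "only" and "open" are said of these compounds alone.

Compound 1 `CCCc1ccc(C#CC#Cc2cn([C@H]3C[C@H](O)[C@@H](CO)O3)c(=O)[nH]c2=O)cc1` gives 52000 nM in an ADME assay on HEL cells (Homo sapiens), read by cell counting, with a stated time of 3 days; a lower number here means that less compound is tolerated, a higher number that more compound is tolerated. For the measured compounds named here, compound 2 `O=c1[nH]c(=O)n([C@H]2C[C@H](O)[C@@H](CO)O2)cc1C#CC#Cc1ccc([N+](=O)[O-])cc1` gives 89000 nM in this assay; the change is a 1.7-fold higher number from compound 1 to compound 2 (0.23 log units; within the scatter), so compound 2 stands level with compound 1 within the scatter, and the two numbers so far span no real difference.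

Compound 3 `O=c1[nH]c(=O)n([C@H]2C[C@H](O)[C@@H](CO)O2)cc1C#CC#CCC1CCCC1` differs from compound 2 by cyclopentylmethyl in place of 4-nitrophenyl on a triple-bonded carbon. Going by the values given here, the only measured step, a 1.7-fold higher number from compound 1 to compound 2 (0.23 log units; within the scatter), swaps one substituent on the aromatic ring and bears on this change only loosely, since here the whole aromatic ring leaves and a saturated ring enters; it showed nothing beyond the scatter. Among the compounds with values here, no step so far moves this assay, so no step beyond the scatter is expected from compound 2 to compound 3, that is a 1.3-fold lower number from compound 2 to compound 3 (0.10 log units; within the scatter). Compound 3 is therefore estimated at 70000 nM in this assay, with a range from 25000 nM to 200000 nM.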

Compound 3, half-maximal cytotoxic concentration: 89000 nM
Compound 3: the middle estimate sits 1.3-fold (0.10 log units) below what was measured; measured number inside the range.
By their numbers in this assay, from the lowest: compounds 1, 2 and 3 (each within the scatter of the next).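

The earlier compounds shown here varied only a substituent on the aromatic ring, whereas compound 3 removes that ring from the triple-bonded carbon altogether and puts a saturated ring in its place. Even this larger change leaves the reading in this assay within the scatter for both comparisons (no change at the digits printed from compound 2 to compound 3 (within the scatter)) and (a 1.7-fold higher number from compound 1 to compound 3 (0.23 log units; within the scatter)), so an aromatic ring at this position is not needed to keep these numbers level, at least for the three groups shown. No supporting data are available to account for this result.

All three groups shown are neutral and carry a ring. Still open, on these data alone, is whether an amine, a carboxylic acid or a straight hexyl chain on this triple-bonded carbon would give a number beyond the scatter in this assay.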